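Isopropyl in place of methyl on an amide-type nitrogen

The source may hold more compounds than are shown below. What is called first, only, known or untested is meant among the compounds shown, and "the series" means these compounds.

Within the data shown here, in an ADME assay on microsomes from liver (Rattus norvegicus) for pharmacokinetics, using NADPH, with a stated time of 30 min, tested at 1 uM (on this read-out lower numbers stand for slow clearance and higher numbers for fast clearance), compound 1 (`CNC(=O)c1c(-c2ccccc2)c([C@H](C)Nc2ncnc(N)c2C#N)nc2ccc(F)cc12`) gives 15 mL.min-1.g-1, the only exact number so far. Compound 2 (`CCNC(=O)c1c(-c2ccccc2)c([C@H](C)Nc2ncnc(N)c2C#N)nc2ccc(F)cc12`) reads < 14 mL.min-1.g-1, which is a limit of the assay and not a number. Methyl in place of hydrogen on a saturated chain carbon bound to an amide-type nitrogen separates these two compounds. Compound 3 (`CC(C)NC(=O)c1c(-c2ccccc2)c([C@H](C)Nc2ncnc(N)c2C#N)nc2ccc(F)cc12`) instead carries isopropyl in place of methyl on an amide-type nitrogen. Among the measured compounds shown here, only one measured step bears on this change, and it alters the same amide side chain in a different way. With that step being an at least 1.0-fold lower number from compound 1 to compound 2 (0.02 log units; that floor lies within the scatter), no shift beyond the scatter is expected in this assay. The estimated step is a 1.1-fold higher number from compound 1 to compound 3 (0.03 log units; within the scatter). For compound 3 the expected value is 16 mL.min-1.g-1, with an estimated range from 9 mL.min-1.g-1 to 32 mL.min-1.g-1.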

Compound 3, intrinsic clearance in microsomes: < 14 mL.min-1.g-1
Compound 3: no number, only a limit; the forecaster's own chance of this, stated with the estimate: 45%; at least 1.1-fold (0.05 log units) between middle value and limit.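

In this assay compound 3 gives a limit and not a number, so isopropyl on the amide-type nitrogen shows no rise over the methyl of compound 1, with the change read as an at least 1.0-fold lower number from compound 1 to compound 3 (0.02 log units; that floor lies within the scatter). Compound 2 and compound 3 both stop at a limit, so the step between them cannot be read. The two changes to the amide side chain thus end at the same limit, and how far either compound lies beyond it stays unknown: the limit of < 14 mL.min-1.g-1 in this assay, at which 2 of the 3 values shown sit.

The compounds shown leave open whether a step beyond the scatter lies hidden behind this limit. They also leave open how a cyclopropyl group, a longer chain or an amine on this amide-type nitrogen would read in this assay.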